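The source may hold more compounds than are shown below. What is called first, only, known or untested is meant among the compounds shown, and "the series" means these compounds.

Measured so far:
compound 1 `Fc1ccc(/C=C/c2ccccc2F)cc1F` — > 15000 nM
compound 2 `Fc1cccc(/C=C/c2ccccc2F)c1` — > 15000 nM
compound 3 `Fc1ccccc1/C=C/c1ccccc1F` — 4300 nM

In an assay on HepG2 cells for activation of nuclear factor erythroid 2-related factor 2 (Homo sapiens), read by a luciferase reporter, with a stated time of 5 h (a lower number here means that less compound is needed, a higher number that more compound is needed for the effect), compound 1 reaches only a limit of the assay, > 15000 nM. Compound 2 likewise stops at a limit, > 15000 nM. Among the compounds with values here, compound 3 gives 4300 nM, the one real number here. The change from compound 2 to compound 1 is fluoro in place of hydrogen on an aromatic carbon, and its size is a step that the two limits leave unreadable from compound 2 to compound 1, because the limit of > 15000 nM in this assay, at which 2 of the 3 values shown sit, holds both values. How the core of compound 3 differs from that of compound 2 is not broken down here. Compound 4 `Fc1ccccc1/C=C/c1c(F)cccc1F` carries the same kind of change, (fluoro in place of hydrogen on an aromatic carbon), but its place differs: ortho to a group of 9 heavy atoms and meta to a fluoro group, rather than ortho to a fluoro group and para to a group of 9 heavy atoms. With the earlier step unreadable, the step from compound 3 to compound 4 is expected to be a 1.0-fold higher number from compound 3 to compound 4 (0.02 log units; within the scatter), resting on compound 3 at 4300 nM. Compound 4 is therefore estimated at 4500 nM, between 1200 nM and 15000 nM.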

Compound 4, half-maximal effective concentration: 1400 nM
Beside the measured number, compound 4's estimate is 3.2-fold (0.51 log units) above it; the range from low to high includes it.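

In this assay, fluoro in place of hydrogen gives a 3.1-fold lower number from compound 3 to compound 4 (0.49 log units; beyond the scatter), so on the core of compound 3 this change means that less compound is needed, by a modest step beyond the usual scatter. The same kind of change on the core of compound 2 cannot be read, because compound 2 and compound 1 both stop at an assay limit: the limit of > 15000 nM in this assay, at which 2 of the 4 values shown sit. One readable step, at a different place from the unreadable one, does not show whether the change carries from one core to another.

The compounds shown carry only fluoro groups, so it remains open how an amine, a methoxy group or a carboxylic acid would read at the same place.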